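Aryl group on the aromatic nitrogen: working notes

The compounds below may be only part of what the source reports. "The series", "measured", "known", "first", "only" and "open" are said of these compounds alone.

Measured so far in a functional assay on PC-12 cells (Rattus norvegicus) for cytotoxicity, read by MTT assay, with stated times of 2 h and 24 h, tested at 10 uM; a lower number here means a weaker effect, a higher number a stronger effect of the compound at the concentration tested:

compound 1 `Oc1cc(C(F)(F)F)ccc1-c1nc(-c2ccccc2O)n(-c2ccc(Cl)cc2)n1` — 96.1%
compound 2 `Oc1cc(C(F)(F)F)ccc1-c1nc(-c2ccccc2O)n(-c2ccccc2F)n1` — 100%
compound 3 `Oc1cc(C(F)(F)F)ccc1-c1nc(-c2ccccc2O)n(-c2cccc(Cl)c2)n1` — 100%

Compound 1 sits alongside compounds 2 and 3, and all three values lie within the usual scatter of one another. The measured steps bear this out: a number 3.9 percentage points higher from compound 1 to compound 2 (within the scatter), a number 3.9 percentage points higher from compound 1 to compound 3 (within the scatter) and no change at the digits printed from compound 2 to compound 3 (within the scatter). Each of these steps swaps the whole aryl group on the aromatic nitrogen, and none moves the read-out beyond the scatter; the shared core of compound 1 appears to set the response by itself in this series.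

Compound 4 `Oc1cc(C(F)(F)F)ccc1-c1nc(-c2ccccc2O)n(-c2ccc(Cl)cc2Cl)n1` is not yet measured. It differs from compound 1 by chloro in place of hydrogen on an aromatic carbon, so the 4-chlorophenyl of compound 1 becomes 2,4-dichlorophenyl while the rest of the molecule is unchanged. All three measured steps concern the same aryl group, and all were within the scatter, which gives no ground to expect a step beyond the scatter here either. The step from compound 1 to compound 4 is therefore expected to be a number 1.9 percentage points higher from compound 1 to compound 4 (within the scatter). For compound 4 the estimate in this assay is 98%, with a range from 88% to 103%.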

Compound 4, a percentage reported as activity, at one concentration (the size of the read-out at that concentration, not a potency): 95.2%
The estimate for compound 4 lay 2.8 percentage points above the measured number, within the range that was stated.
By their numbers in this assay, from the lowest: compounds 4, 1, 2 and 3 (each within the scatter of the next).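

Adding a chloro group to the 4-chlorophenyl of compound 1, on an aromatic carbon ortho to a large group and meta to the existing chloro group, keeps the first aryl substituent in place and adds a second, unlike the earlier whole-group swaps; in this assay this gives a number 0.9 percentage points lower from compound 1 to compound 4 (within the scatter). The 2,4-dichlorophenyl group also stays within the scatter of the two other aryl groups, with a number 4.8 percentage points lower from compound 3 to compound 4 (within the scatter) and a number 4.8 percentage points lower from compound 2 to compound 4 (within the scatter), so among these four compounds a second substituent on this aryl group produces no step beyond the scatter. No measurement is available that would account for this flat result.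

The aryl groups shown carry only chloro or fluoro substituents, so how this assay responds to an amine, a carboxylic acid or a methoxy group on this aryl group, or to a longer chain in its place, remains open. All four compounds also share the same core, and the effect of replacing its trifluoromethyl group or either of its hydroxyl groups is likewise unresolved.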